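Glutathione-like tripeptide esters: swapping the sulfur substituent

The source may report more compounds than this note shows. Statements on the series, on what has been measured and on what is new or still open speak of the compounds shown alone.

Two closely related tripeptide esters have been measured in a functional assay on K562 cells (Homo sapiens) for cytotoxicity (on this read-out higher numbers stand for weaker inhibition and lower numbers for stronger inhibition), so far. Compound 1 `COC(=O)CNC(=O)C(CSCc1ccc(Br)cc1)NC(=O)CCC(NC(=O)OCc1ccccc1)C(=O)OC` carries a 4-bromobenzyl group on its sulfur, and in this assay compound 1 gives 16.7 uM. Among the measured compounds shown here, compound 2 `COC(=O)CNC(=O)C(CSC(=O)OCc1ccccc1)NC(=O)CCC(NC(=O)OCc1ccccc1)C(=O)OC` carries a benzyloxycarbonyl group at the same sulfur instead, and in this assay compound 2 gives 1.26 uM, the lowest of the two numbers; the only step between them is a 13-fold lower number from compound 1 to compound 2 (1.12 log units; beyond the scatter).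

Compound 3 `COC(=O)CNC(=O)C(CSc1ccc([N+](=O)[O-])cc1[N+](=O)[O-])NC(=O)CCC(NC(=O)OCc1ccccc1)C(=O)OC` is the next member of the series. It differs from compound 2 in one place: 2,4-dinitrophenyl in place of benzyloxycarbonyl on a sulfur. For the measured compounds named here, no measured step covers this exact exchange. Going by the values given here, the one step that bears on it, from compound 1 to compound 2, shows that the group on the sulfur can move this assay by a large amount, and that the arene-bearing substituent of compound 1 sat at the higher number. Since compound 3 again carries an arene on the sulfur rather than the benzyloxycarbonyl of compound 2, a shift back toward higher numbers is expected, estimated as a 6.3-fold higher number from compound 2 to compound 3 (0.80 log units; beyond the scatter). The value expected for compound 3 in this assay is therefore 8 uM, with a range from 2 uM to 30 uM.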

Compound 3, concentration for 50% inhibition: 23.4 uM
Estimate against measurement, compound 3: 2.9-fold (0.47 log units) below; measured number inside the range.
By their numbers in this assay, from the lowest: compound 2; then compounds 1 and 3 (each within the scatter of the next).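

In this assay, the change from benzyloxycarbonyl to 2,4-dinitrophenyl on the sulfur gives a 19-fold higher number from compound 2 to compound 3 (1.27 log units; beyond the scatter), so compound 2 now stands apart from two different sulfur substituents rather than one. The other comparison, a 1.4-fold higher number from compound 1 to compound 3 (0.15 log units; within the scatter), leaves 2,4-dinitrophenyl and 4-bromobenzyl indistinguishable here despite their different make-up, and the aromatic ring alone does not mark out compound 2, as benzyloxycarbonyl and 2,4-dinitrophenyl each carry one six-membered aromatic ring of carbon; among these three compounds, only compound 2 has a carbonyl directly on the sulfur. No measurement is available that would explain the difference at this position.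

The compounds shown leave open whether the lower number of compound 2 goes with that carbonyl on the sulfur or with the whole benzyloxycarbonyl group. An acetyl or ethoxycarbonyl group on the sulfur would keep the carbonyl without the benzyl part, and a plain benzyl group would keep the benzyl part without the carbonyl, so either could help separate the two.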